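Nitrile to primary amide on a shortened ether chain

A few compounds are considered here, and "the series" means these few. Any claim that something is new, unique, unknown or untested is made for them only; others in the source may bear on it.

Measured compounds:
compound 1 `CC(=O)c1cc(C(C)=O)c(OCCCCC#N)cc1O`: 0%
compound 2 `CCc1cc(C(C)=O)c(O)cc1OCCCCC(C)(C)C#N`: 30%
compound 3 `CCc1cc(C(C)=O)c(O)cc1OCCCCCCCC(C)(C)C#N`: 29%

Of the compounds shown here, three have been tested in an assay on isolated protein for binding affinity to leukotriene B4 receptor 1 (Homo sapiens), tested at 1 uM; on this read-out lower numbers stand for less inhibition and higher numbers for more inhibition at the one concentration tested (going by the name of the read-out). Compound 2 gives the highest number of the three, but compound 3 sits within the scatter of it, so no order between those two can be claimed; only compound 1 lies clearly beneath compound 2.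

Compound 4 `CCc1cc(C(C)=O)c(O)cc1OCCCC(C)(C)C(N)=O` has not yet been measured. It differs from compound 2 by one change: 1-carbamoyl-1-methylethyl in place of 2-cyano-2-methylpropyl on a saturated chain carbon, three bonds along the chain from an oxygen on an aromatic ring. Among the measured compounds shown here, only one measured step touches this region of the molecule, the one from compound 2 to compound 3, where lengthening the cyano-bearing chain gave a number 1 percentage points lower from compound 2 to compound 3 (within the scatter). For the measured compounds named here, that step speaks only to chain length, not to the nitrile itself; no measured pair shows a nitrile exchanged for a carbamoyl group, and compound 1 differs from compound 2 in more than one place, so it offers no isolated comparison.

Compound 4 is therefore expected to give roughly 20% in this assay, with a plausible range from 0% to 45%, a step of about a number 10 percentage points lower from compound 2 to compound 4 (within the scatter) that may well stay within the scatter.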

Compound 4, a percentage reported as inhibition, at one concentration (the size of the read-out at that concentration, not a potency): 51%
Compound 4: middle estimate off by 31 percentage points, on the low side; the measured number lies above the stated range.
By their numbers in this assay, from the lowest: compound 1; then compounds 3 and 2 (each within the scatter of the next); then compound 4.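

In this assay, 1-carbamoyl-1-methylethyl in place of 2-cyano-2-methylpropyl gives a number 21 percentage points higher from compound 2 to compound 4 (beyond the scatter), so a change at this position can move the number beyond the scatter. The earlier step in this region, a number 1 percentage points lower from compound 2 to compound 3 (within the scatter), altered the chain that carries the nitrile and stayed within the scatter, which left open whether this part of the molecule responded to change at all. Nothing shown here explains the rise.

The exchange replaces the nitrile with a carbamoyl group and also shortens the chain, so the compounds shown cannot separate the two contributions. Also open, from the compounds shown here alone, is how a carboxylic acid or an amine in place of the carbamoyl group would read, and whether a carbamoyl group on the longer chain of compound 3 would give a similar number.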